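Moving the methoxy group on the phenoxyacetamide piperazine

The source may hold more compounds than are shown below. What is called first, only, known or untested is meant among the compounds shown, and "the series" means these compounds.

Compound 1 `O=C(COc1ccc2ccccc2c1)N1CCN(C(c2ccc(Br)cc2)c2ccc(Br)cc2)CC1` gives 30.2% in a functional assay on PC-12 cells (Rattus norvegicus) for cytotoxicity, read by MTT assay, with a stated time of 24 h, tested at 10 uM; a higher number here means a stronger effect of the compound at the concentration tested, a lower number a weaker effect.
Compound 2 `COc1ccc(OCC(=O)N2CCN(C(c3ccc(Br)cc3)c3ccc(Br)cc3)CC2)cc1` gives 50.3% in this assay.

Compound 2 stands highest of the two numbers; the nearest is compound 1, separated by a number 20.1 percentage points higher from compound 1 to compound 2 (beyond the scatter). Compound 3 `COc1ccccc1OCC(=O)N1CCN(C(c2ccc(Br)cc2)c2ccc(Br)cc2)CC1` differs from compound 2 by 2-methoxyphenyl in place of 4-methoxyphenyl on an oxygen on a saturated carbon. Among the measured compounds shown here, the one measured step exchanged the whole aryl group rather than moving a methoxy group, so no step bears directly on this change. The step from compound 2 to compound 3 is therefore expected to be small, around a number 6.3 percentage points lower from compound 2 to compound 3 (within the scatter). Compound 3 is estimated at 44%, with a range from 24% to 64%.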

Compound 3, a percentage reported as activity, at one concentration (the size of the read-out at that concentration, not a potency): 6.67%
Beside the measured number, compound 3's estimate is 37.3 percentage points above it; the measured number lies below the stated range.
By their numbers in this assay, from the lowest: compound 3; then compound 1; then compound 2.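

Moving the methoxy group, with the same atoms joined differently, gives a number 43.6 percentage points lower from compound 2 to compound 3 (beyond the scatter) in this assay, so the number at this place depends on where the methoxy group sits and not only on which aryl group is present. Replacing naphthalen-2-yl with 2-methoxyphenyl gives a number 23.5 percentage points lower from compound 1 to compound 3 (beyond the scatter) and leaves compound 3 lowest of the three, while 4-methoxyphenyl in compound 2 gives the highest number. Nothing shown here explains the size of this change.

The compounds shown leave open whether an ethoxy group or a carboxylic acid in place of the methoxy group would keep the number of compound 2 or that of compound 3. They also do not tell what the number reflects beyond this one concentration.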